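Aryl sulfonyl swaps tested for cytotoxicity

The compounds below may be only part of what the source reports. "The series", "measured", "known", "first", "only" and "open" are said of these compounds alone.

Measured so far in an ADME assay on HCT-116 cells (Homo sapiens) for cytotoxicity, read by CellTiter-Glo, with a stated time of 72 h; on this read-out lower numbers stand for stronger inhibition and higher numbers for weaker inhibition:
- compound 1 `CCc1ccc(S(=O)(=O)N2CCC(N3CCC(C)CC3)CC2)cc1` gives > 5000 nM, a limit of the assay
- compound 2 `Cc1ccc(S(=O)(=O)N2CCC(N3CCC(C)CC3)CC2)cc1C` gives > 5000 nM, a limit of the assay
- compound 3 `CC1CCN(C2CCN(S(=O)(=O)c3nccn3C)CC2)CC1` gives > 10000 nM, a limit of the assay

Compound 3 stands at a limit in this assay, and the two further values shown are limits as well, so it cannot be placed relative to either of them. The three measured steps, a step that the two limits leave unreadable from compound 1 to compound 2, a step that the two limits leave unreadable from compound 1 to compound 3 and a step that the two limits leave unreadable from compound 2 to compound 3, are all left unreadable by the two limits. The evidence is the limit of > 10000 nM in this assay, at which 1 of the 3 values shown sits, and (the limit of > 5000 nM in this assay, at which 2 of the 3 values shown sit).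

Compound 4 `CC1CCN(C2CCN(S(=O)(=O)c3ccc(Cl)cc3Cl)CC2)CC1` is not yet measured. It differs from compound 3 by 2,4-dichlorophenyl in place of 1-methyl-1H-imidazol-2-yl on a sulfonyl sulfur. The three measured steps bear on this change in that each of them is also an exchange of the group on the sulfonyl sulfur, but none of them has a readable size or direction, so no step beyond the scatter can be predicted for compound 4 in this assay; the expectation is that it again sits at or near a limit of the assay. The step from compound 3 to compound 4 is therefore estimated as an at least 1.1-fold lower number from compound 3 to compound 4 (0.04 log units; that floor lies within the scatter). For compound 4 the expected value is 9000 nM, with a range of 3000 nM to 25000 nM.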

Compound 4, half-maximal inhibitory concentration: > 5000 nM
Compound 4: no number, only a limit (the forecaster's own chance of this, stated with the estimate: 70%); the middle value lies beyond the limit too.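

In this assay compound 4 gives > 5000 nM, a limit of the assay. The steps from compound 1, compound 2 and compound 3 to compound 4 therefore cannot be read: the limit of > 5000 nM in this assay, at which 3 of the 4 values shown sit.

The compounds shown leave open whether any exchange of the group on the sulfonyl sulfur shifts the read-out of this assay at all, and by how much.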